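A few compounds are considered here, and "the series" means these few. Any claim that something is new, unique, unknown or untested is made for them only; others in the source may bear on it.

Of the compounds shown here, three have so far been measured in an assay for inhibition of Catechol O-methyltransferase (Rattus norvegicus), read by fluorescence and spectrophotometry; a lower number here means a stronger inhibitor, a higher number a weaker inhibitor. Compound 1, with the structure `O=C(/C=C/c1cccc(O)c1)c1cc(O)c(O)c([N+](=O)[O-])c1`, gives 140 nM in this assay. Compound 2, with the structure `N#Cc1cccc(/C=C/C(=O)c2cc(O)c(O)c([N+](=O)[O-])c2)c1`, differs from compound 1 in one place only, namely (cyano in place of hydroxy on an aromatic carbon), and in this assay compound 2 gives 240 nM. The step this change made is a 1.7-fold higher number from compound 1 to compound 2 (0.23 log units; within the scatter), so the two values cannot be told apart with confidence.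

Compound 3, with the structure `CC(=O)N1N=C(c2cc(O)c(O)c([N+](=O)[O-])c2)CC1c1cccc(O)c1`, is built on a different core; how its core differs from that of compound 1 is not broken down here. In this assay compound 3 gives 75 nM. Its value and that of compound 1 lie within the usual scatter of each other, while its gap to compound 2 lies beyond it.

Compound 4, with the structure `CC(=O)N1N=C(c2cc(O)c(O)c([N+](=O)[O-])c2)CC1c1cccc(C#N)c1`, is the counterpart of compound 3: it carries the same change that turned compound 1 into compound 2, namely (cyano in place of hydroxy on an aromatic carbon), at a place described in the same words. Because the earlier step was a 1.7-fold higher number from compound 1 to compound 2 (0.23 log units; within the scatter), the step from compound 3 to compound 4 is expected to be of similar size, which would read a 1.7-fold higher number from compound 3 to compound 4 (0.24 log units; within the scatter). On this basis compound 4 is estimated to give about 130 nM in this assay, most likely somewhere between 60 nM and 280 nM.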

Compound 4, half-maximal inhibitory concentration: 79 nM
Compound 4: middle estimate off by 1.6-fold (0.22 log units), on the high side; the range from low to high includes it.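

On the core of compound 3, putting cyano in place of hydroxy on the aromatic carbon gives a 1.1-fold higher number from compound 3 to compound 4 (0.02 log units; within the scatter), so these two values cannot be told apart. Set beside the same change on the core of compound 1, the new step does not differ from the earlier one by more than such pairs of steps normally do: the same change on two cores in this assay, a 1.7-fold higher number (0.23 log units; within the scatter) from compound 1 to compound 2 and a 1.1-fold higher number (0.02 log units; within the scatter) from compound 3 to compound 4, 1.6-fold (0.21 log units) apart, within the scatter of two such steps. This shows that, in these two pairs, the change carries from one core to the other without a detectable difference in the size of its step; it does not show that the change has no effect at all or that the two cores respond identically, as each step is small enough to hide a real difference, and two pairs set no rule for the whole series.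

Every compound shown has either hydroxy or cyano at this place on the ring, so it remains open what an amine, a carboxylic acid or a methoxy group would do there on either core. As far as these compounds go, whether the same swap would behave alike on a third core also remains open.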